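Amide variation on the diaryl aminothiophene carboxamide series

The compounds below may be only part of what the source reports. "The series", "measured", "known", "first", "only" and "open" are said of these compounds alone.

Compound 1 `Nc1sc(-c2ccc(Cl)cc2)c(-c2ccc(Cl)cc2)c1C(=O)N1CCCCC1=O` sits at the low end of the numbers so far: in a functional assay on PC-3 cells (Homo sapiens) for inhibition, read by sulforhodamine B assay, with a stated time of 72 h (on this read-out lower numbers stand for stronger inhibition and higher numbers for weaker inhibition), compound 1 gives 4940 nM, the lowest of the two numbers shown, with compound 3 `Nc1sc(-c2ccc(Cl)cc2)c(-c2ccc(Cl)cc2)c1C(=O)N1CCOCC1` nearest at 11700 nM. Compound 2 `Nc1sc(-c2ccc(Cl)cc2)c(-c2ccc(Cl)cc2)c1C(=O)Nc1ccccc1` reaches only the assay limit, > 50000 nM in this assay. The steps read a 2.4-fold higher number from compound 1 to compound 3 (0.37 log units; beyond the scatter) and an at least 10-fold higher number from compound 1 to compound 2 (1.00 log units; beyond the scatter); the latter rests on (the limit of > 50000 nM in this assay, at which 1 of the 3 values shown sits).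

Compound 4 `CC(C)CNC(=O)c1c(N)sc(-c2ccc(Cl)cc2)c1-c1ccc(Cl)cc1` differs from compound 1 by isobutylamino in place of 2-oxopiperidin-1-yl on a carbonyl carbon. Both measured changes at this carbonyl carbon moved the number upward, modestly for morpholin-4-yl and at least modestly for anilino; isobutylamino is expected to behave similarly, with a step of a 3.0-fold higher number from compound 1 to compound 4 (0.48 log units; beyond the scatter). Compound 4 is therefore estimated at 15000 nM, within 5000 nM to 50000 nM in this assay.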

Compound 4, half-maximal inhibitory concentration: 13200 nM
For compound 4 the middle estimate is 1.1-fold (0.06 log units) above the measured one; low and high end bracket the measured number.
By their numbers in this assay, from the lowest: compound 1; then compounds 3 and 4 (each within the scatter of the next). At a limit, above all of these: compound 2.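

With isobutylamino the series gains an open-chain group at this carbonyl carbon, and it gives a 2.7-fold higher number from compound 1 to compound 4 (0.43 log units; beyond the scatter), so 2-oxopiperidin-1-yl still holds the lowest number. In this assay, ring and open chain are not separated here, with a 1.1-fold higher number from compound 3 to compound 4 (0.05 log units; within the scatter). Isobutyl in place of phenyl on the amide-type nitrogen gives an at least 3.7-fold lower number from compound 2 to compound 4 (0.57 log units; beyond the scatter), a step that rests on a limit: the limit of > 50000 nM in this assay, at which 1 of the 4 values shown sits.

Going by these compounds, whether the lower number of compound 1 depends on its ring carbonyl stays open. Piperidin-1-yl on the same carbonyl carbon would separate that carbonyl from the ring itself.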